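From methyl to fluoro in compound 4

A few compounds are considered here, and "the series" means these few. Any claim that something is new, unique, unknown or untested is made for them only; others in the source may bear on it.

Measured in an ADME assay on HEK-293T cells (Homo sapiens) for inhibition, read by CCK-8 assay, with a stated time of 48 h, tested at 20 uM; a higher number here means more inhibition of growth at the concentration tested, a lower number less inhibition of growth:
- compound 1 `N#C/C(=C\c1ccccc1OS(=O)(=O)c1ccc(F)cc1)C(=O)Nc1nnc(Cc2cccc3ccccc23)s1` gives 15%
- compound 2 `N#C/C(=C\c1ccccc1OS(=O)(=O)c1ccc(F)cc1)C(=O)Nc1nnc(Cc2ccc(Cl)cc2)s1` gives 14%
- compound 3 `Cc1ccc(Cc2nnc(NC(=O)/C(C#N)=C/c3ccccc3OS(=O)(=O)c3ccc(C)cc3)s2)cc1` gives 22%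

The three values lie within the scatter of one another, so compound 3 stands apart from neither compound 1 nor compound 2. Compound 4 `Cc1ccc(Cc2nnc(NC(=O)/C(C#N)=C/c3ccccc3OS(=O)(=O)c3ccc(F)cc3)s2)cc1` differs from compound 3 by fluoro in place of methyl on an aromatic carbon, para to a large group. Within the data shown here, no measured step makes this exchange. Among the measured compounds shown here, the only measured step, a number 1 percentage points lower from compound 1 to compound 2 (within the scatter), concerns another group. Compound 1 at 15% and compound 2 at 14% already carry the (4-fluorophenyl)sulfonyl group. In this assay nothing beyond the scatter is therefore expected, only an estimated a number 5 percentage points lower from compound 3 to compound 4 (within the scatter). For compound 4 the estimated value is 17%, with an expected range from 8% to 27%.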

Compound 4, percent growth inhibition at one concentration: 11%
The estimate for compound 4 lay 6 percentage points above the measured number; the range from low to high includes it.
By their numbers in this assay, from the lowest: compounds 4, 2, 1 and 3 (each within the scatter of the next, the first and the last beyond it).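

In this assay, the sulfonyl ring's substituent, para to a large group, now has a measured exchange of methyl for fluoro: a number 11 percentage points lower from compound 3 to compound 4 (beyond the scatter). Among the compounds carrying the (4-fluorophenyl)sulfonyl group, the exchanges at the other end stay small: a number 3 percentage points lower from compound 2 to compound 4 (within the scatter), and a number 4 percentage points lower from compound 1 to compound 4 (within the scatter). Nothing available accounts for the step at the sulfonyl ring. As far as these compounds go, whether fluoro in place of methyl gives a similar step with the naphthalen-1-yl or 4-chlorophenyl group stays open. So does the effect of an amine or a methoxy group at this position.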